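This account rests on a few compounds, and the source may have more. Where it says the series, first, only, none or still open, it means among the compounds named here.

In a functional assay (spleen, spleen) for activation, with Mus musculus as the target (on this read-out lower numbers stand for an effect already at smaller amounts and higher numbers for an effect only at larger amounts of compound), the measured compounds are:
compound 1 `Cc1nc(N)c2nc(O)n(Cc3ccccc3)c2n1`: 1 uM
compound 2 `Nc1nc(N)c2nc(O)n(Cc3ccccc3)c2n1`: 10 uM
compound 3 `CCCC[S+]([O-])c1nc(N)c2nc(O)n(Cc3ccccc3)c2n1`: 0.01 uM

Compound 3 gives the lowest number of the three; the steps of a 100-fold lower number from compound 1 to compound 3 (2.00 log units; beyond the scatter) and a 1000-fold lower number from compound 2 to compound 3 (3.00 log units; beyond the scatter) are both large and beyond the scatter. Compound 4 `CCCCNc1nc(N)c2nc(O)n(Cc3ccccc3)c2n1` differs from compound 3 in one place: a group of 5 heavy atoms (4 carbon, 1 nitrogen; no ring) in place of a group of 6 heavy atoms (4 carbon, 1 oxygen, 1 sulfur; no ring), on an aromatic carbon. The four-carbon chain is kept, but the sulfur and oxygen are gone and a nitrogen enters. The steps bearing on this are a 100-fold lower number from compound 1 to compound 3 (2.00 log units; beyond the scatter) and a 1000-fold lower number from compound 2 to compound 3 (3.00 log units; beyond the scatter), which show that the six-heavy-atom group on this aromatic carbon carries the gain over compound 1 and compound 2. Since compound 4 keeps the chain but not that group, a moderate rise is expected, a 10-fold higher number from compound 3 to compound 4 (1.00 log units; beyond the scatter). Compound 4 is estimated at 0.1 uM, with a range from 0.01 uM to 1 uM.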

Compound 4, minimum effective concentration: 1 uM
Beside the measured number, compound 4's estimate is 10-fold (1.00 log units) below it, and the stated range covers the measured number.
By their numbers in this assay, from the lowest: compound 3; then compounds 1 and 4 (each within the scatter of the next); then compound 2.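

In this assay, the four-carbon chain alone does not hold the gain at this aromatic carbon, since butylamino in place of the earlier group gives a 100-fold higher number from compound 3 to compound 4 (2.00 log units; beyond the scatter). Butyl on the nitrogen of the amino group does count, with a 10-fold lower number from compound 2 to compound 4 (1.00 log units; beyond the scatter). Yet butylamino in place of methyl gives no change at the digits printed from compound 1 to compound 4 (within the scatter), so the chain on nitrogen only matches methyl here.

Nothing measured here accounts for these steps. Going by these compounds, whether a butoxy group, a butylthio group or a longer chain on the nitrogen would behave like compound 3 or like compound 4 remains open.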